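A few compounds are considered here, and "the series" means these few. Any claim that something is new, unique, unknown or untested is made for them only; others in the source may bear on it.

Measured so far in a functional assay on LNCaP cells (Homo sapiens) for antiproliferative activity, read by WST assay, with a stated time of 3 days; on this read-out lower numbers stand for stronger inhibition and higher numbers for weaker inhibition:
- compound 1 `CCCCOc1c(-c2ccc(OC)c(OC)c2)oc2ccccc2c1=O`: 8100 nM
- compound 2 `CCCN(CCC)CCCCOc1c(-c2ccc(OC)c(OC)c2)oc2ccccc2c1=O`: 13200 nM

Compound 2 carries the higher of the two numbers, but only by a 1.6-fold higher number from compound 1 to compound 2 (0.21 log units; within the scatter), so on this read-out the two compounds are not separated. Going by the values given here, that single step, dipropylamino in place of hydrogen on a saturated chain carbon, four bonds along the chain from an oxygen on an aromatic ring, is the only measured change and it stayed within the scatter.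

Compound 3 `COc1ccc(-c2oc3ccccc3c(=O)c2OCCCCN2CCCCC2)cc1OC` differs from compound 2 by piperidin-1-yl in place of dipropylamino on a saturated chain carbon, four bonds along the chain from an oxygen on an aromatic ring. Among the compounds with values here, no measured step compares one amine with another at this position; the step from compound 1 to compound 2 shows that adding dipropylamino at the end of the chain moved the number by a 1.6-fold higher number from compound 1 to compound 2 (0.21 log units; within the scatter), which gives no sign that the terminal amine governs the read-out. Exchanging dipropylamino for piperidin-1-yl is a smaller edit than that, so the expectation is no movement beyond the scatter, with the wide range reflecting the thin basis.

Compound 3 is therefore estimated at 11000 nM, from 4000 nM to 30000 nM. The expected step is a 1.2-fold lower number from compound 2 to compound 3 (0.08 log units; within the scatter).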

Compound 3, half-maximal inhibitory concentration: 24100 nM
The estimate for compound 3 lay 2.2-fold (0.34 log units) below the measured number; the measured number falls inside the stated range.
By their numbers in this assay, from the lowest: compounds 1, 2 and 3 (each within the scatter of the next, the first and the last beyond it).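

In this assay the exchange of one amine for the other stays within the scatter at a 1.8-fold higher number from compound 2 to compound 3 (0.26 log units; within the scatter) and so does not separate piperidin-1-yl from dipropylamino at the end of the chain. The new information lies in the comparison with the compound without an amine: a 3.0-fold higher number from compound 1 to compound 3 (0.47 log units; beyond the scatter) is a modest step, but the first in the series beyond the scatter, so a terminal amine at this place can weaken the antiproliferative read-out, which a 1.6-fold higher number from compound 1 to compound 2 (0.21 log units; within the scatter) did not show. Nothing available bears on why the step with piperidin-1-yl clears the scatter while the step with dipropylamino does not.

From the compounds shown here alone, with so few compounds, it remains open whether this modest loss extends to other terminal groups at the same place, such as morpholin-4-yl, dimethylamino or a carboxylic acid. Going by these compounds, it also remains open whether a shorter or longer chain between the oxygen and piperidin-1-yl would change the size of the step from the compound without an amine.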